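The compounds below may be only part of what the source reports. "The series", "measured", "known", "first", "only" and "open" are said of these compounds alone.

Working notes on the series, read in a functional assay on K562 cells (Homo sapiens) for inhibition, read by sulforhodamine B assay, with a stated time of 48 h; a higher number here means a weaker inhibitor of growth, a lower number a stronger inhibitor of growth. Compound 1 (`CC1(/C=C/c2ccccc2)C=CC(=O)O1`) gives > 1000000 nM, which is a limit of the assay and not a number. Compound 2 (`CC1(/C=C/c2cccc(O)c2)C=CC(=O)O1`) gives > 1000000 nM, which is likewise a limit. Compound 2 therefore has no number of its own and stands at the limit of > 1000000 nM in this assay, at which 2 of the 2 values shown sit.

Compound 3 (`COc1cccc(/C=C/C2(C)C=CC(=O)O2)c1`) differs from compound 2 by methyl in place of hydrogen on an oxygen on an aromatic ring, or hydroxy to methoxy. Going by the values given here, the only measured step is a step that the two limits leave unreadable from compound 1 to compound 2, and it concerns the hydroxy group itself, so no size can be carried over to this change. Among the compounds with values here, the expectation therefore rests on the position of compound 2 at > 1000000 nM, with no sizeable step foreseen in this assay. Another limit is the most likely result, and any number returned could only indicate stronger inhibition of growth. The estimated change is an at least 1.2-fold lower number from compound 2 to compound 3 (0.09 log units; that floor lies within the scatter), and it is expected to remain poorly defined against a limit. For compound 3 the expected value is 800000 nM, with an estimated range of 200000 nM to 1000000 nM.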

Compound 3, concentration for total growth inhibition: > 1000000 nM
Compound 3 gave a limit, no number (the forecaster's own chance of this, stated with the estimate: 70%); middle value at least 1.2-fold (0.09 log units) away from the limit.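

The steps among compound 1, compound 2 and compound 3 in this assay cannot be read, and all three compounds sit at a limit rather than a number: the limit of > 1000000 nM in this assay, at which 3 of the 3 values shown sit.

The compounds shown leave open whether any change to the aromatic ring or the shared core gives a measurable number in this read-out, and how hydroxy and methoxy compare.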